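The source may hold more compounds than are shown below. What is called first, only, known or untested is meant among the compounds shown, and "the series" means these compounds.

The series shares the core seen in compound 1 `Cc1ccccc1Nc1nc(Nc2cccnc2)ncc1Cl`; compound 2 `Cc1ccccc1Nc1nc(NCc2ccco2)ncc1Cl` carries a (furan-2-yl)methyl where compound 1 carries pyridin-3-yl on a nitrogen on an aromatic ring. In an ADME assay on L02 cells (Homo sapiens) for inhibition, read by CCK-8 assay, with a stated time of 48 h (a lower number here means a stronger inhibitor of growth, a higher number a weaker inhibitor of growth), compound 1 gives 22900 nM. For compound 2 the result in this assay is only a limit, > 100000 nM, so compound 2 sits at the weak end of the two values shown (the limit of > 100000 nM in this assay, at which 1 of the 2 values shown sits). Within the data shown here, the single measured step is an at least 4.3-fold higher number from compound 1 to compound 2 (0.64 log units; beyond the scatter). Compound 3 `Cc1ccccc1Nc1nc(NCc2ccncc2)ncc1Cl` differs from compound 2 as follows: pyridin-4-yl in place of furan-2-yl on a saturated chain carbon bound to a nitrogen on an aromatic ring. This change brings a pyridyl back, now on a saturated chain carbon rather than directly on a nitrogen on an aromatic ring. Among the measured compounds shown here, the one measured step bears on it only loosely and ran in the weakening direction; a partial return toward compound 1 is possible but not secure. A step of an at least 1.2-fold lower number from compound 2 to compound 3 (0.09 log units; that floor lies within the scatter) is expected. Compound 3 is estimated at 80000 nM, within 25000 nM to 250000 nM, with a fair chance that only a limit is reported again.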

Compound 3, concentration for 50% growth inhibition: > 100000 nM
Compound 3 was reported as a limit; the forecaster's own chance of this, stated with the estimate: 50%; middle value at least 1.2-fold (0.09 log units) away from the limit.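

Moving from furan-2-yl to pyridin-4-yl on the saturated chain carbon does not bring the series off the limit in this assay: compound 3 gives > 100000 nM, which is a limit and not a number. With limits on both sides, the step between compound 2 and compound 3 cannot be read. The comparison with the core of compound 1 gives an at least 4.3-fold higher number from compound 1 to compound 3 (0.64 log units; beyond the scatter), so a pyridyl ring as such does not return the reading of compound 1, and (pyridin-4-yl)methyl stays with (furan-2-yl)methyl at the weak end of the values shown: the limit of > 100000 nM in this assay, at which 2 of the 3 values shown sit.

On these data alone, compound 1 and compound 3 differ in both the pyridyl attachment and the saturated chain carbon, so which of these matters stays open. Also open, as far as these compounds go, is how a longer chain ending in an amine would read in this assay.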